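A few compounds are considered here, and "the series" means these few. Any claim that something is new, unique, unknown or untested is made for them only; others in the source may bear on it.

Measured compounds:
Compound 1 `COc1cc(Cl)cc(-c2nn(-c3cccc(NC(=O)Nc4ccc(Cl)c(C(F)(F)F)c4)c3)cc2-c2ccncc2)c1`: 94%
Compound 2 `COc1cc(Cl)cc(-c2nn(-c3cccc(NC(=O)Nc4cccc(C(F)(F)F)c4)c3)cc2-c2ccncc2)c1`: 104%

In a functional assay on K562 cells (Homo sapiens) for inhibition, read by sulforhodamine B assay, with a stated time of 48 h, tested at 0.01 uM (a higher number here means a weaker effect of the compound at the concentration tested, a lower number a stronger effect), compound 2 gives 104%, the highest of the two numbers, and the nearest number is that of compound 1. For the measured compounds named here, the only measured step is a number 10 percentage points higher from compound 1 to compound 2 (within the scatter). Compound 3 `COc1cc(Cl)cc(-c2nn(-c3cccc(NC(=O)c4cccc(C(F)(F)F)c4)c3)cc2-c2ccncc2)c1` differs from compound 2 by 3-(trifluoromethyl)phenyl in place of (3-(trifluoromethyl)phenyl)amino on a carbonyl carbon. Going by the values given here, that measured step changes a chloro on an aromatic carbon, not the carbonyl carbon, so no measured step bears on this change, and no direction beyond the scatter can be inferred. Compound 3 is expected to sit close to compound 2, with a number 6 percentage points lower from compound 2 to compound 3 (within the scatter), estimated at 98% within a range of 80% to 112%.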

Compound 3, a percentage reported as activity, at one concentration (the size of the read-out at that concentration, not a potency): 108%
The estimate for compound 3 lay 10 percentage points below the measured number; measured number inside the range.
By their numbers in this assay, from the lowest: compounds 1, 2 and 3 (each within the scatter of the next, the first and the last beyond it).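

In this assay, the carbonyl carbon now carries 3-(trifluoromethyl)phenyl in place of (3-(trifluoromethyl)phenyl)amino, which gives a number 4 percentage points higher from compound 2 to compound 3 (within the scatter), so removing that nitrogen and its hydrogen-bond donor leaves the read-out within the scatter. The wider replacement, which also removes the chloro, gives a number 14 percentage points higher from compound 1 to compound 3 (beyond the scatter), a modest step. Nothing available explains either step. On these data alone, it remains open how a longer chain, such as a methylene group between the carbonyl carbon and the ring, or an amine on that ring would read here.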